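A few compounds are considered here, and "the series" means these few. Any claim that something is new, unique, unknown or untested is made for them only; others in the source may bear on it.

Measured compounds:
- compound 1, `COc1cc(NC(C)CCCNC(=O)NNC(=O)N(CCO)CCO)c2ncccc2c1`, which in an ADME assay on L6 cells (Rattus norvegicus) for cytotoxicity, read by resazurin assay, with a stated time of 70 h (on this read-out lower numbers stand for stronger inhibition and higher numbers for weaker inhibition), gives 178000 nM
- compound 2, `COc1cc(NC(C)CCCNC(=O)NNC(=O)NC2CCCC2)c2ncccc2c1`, for which this assay reports "not determined" (no result reported)

Going by the values given here, the only number in hand is for compound 1, whose value in this assay is a high one, so in this read-out it stands for weak inhibition of the cells. Compound 2 shares the core of compound 1 but carries a cyclopentyl group on the amide-type nitrogen, and for compound 2 no single number exists in this assay, so where it stands can only be guessed from compound 1.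

Compound 3, `COc1cc(NC(C)CCCNC(=O)NNC(=O)Nc2cccc(C(F)(F)F)c2)c2ncccc2c1`, differs from compound 2 in one place: 3-(trifluoromethyl)phenyl in place of cyclopentyl on an amide-type nitrogen. Among the compounds with values here, no measured pair shows what such a change does in this assay, so the size of the step is unknown; an expectation here is that the number for compound 3 stays in the same broad region as compound 1, with at most a moderate shift toward lower values, beyond the scatter only if at all. Compound 3 is therefore expected to give about 60000 nM in this assay, in a range from 15000 nM to 200000 nM.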

Compound 3, half-maximal inhibitory concentration: 32100 nM
For compound 3 the middle estimate is 1.9-fold (0.27 log units) above the measured one; low and high end bracket the measured number.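

In this assay, putting (3-(trifluoromethyl)phenyl)amino in place of bis(2-hydroxyethyl)amino on a carbonyl carbon gives a 5.5-fold lower number from compound 1 to compound 3 (0.74 log units; beyond the scatter), so the group at this position can move the number by more than repeat measurements would, although the change here is a modest one. This is a comparison of two quite different groups, and the more direct change from cyclopentyl to 3-(trifluoromethyl)phenyl cannot be read, since compound 2 has no single number in this assay. Nothing at hand accounts for the lower number seen with this change.

Going by these compounds alone, the single step cannot tell whether the aromatic ring or the trifluoromethyl group on it goes with the shift, a question that a plain phenyl group at the same place would help to separate. It also leaves open how far the number would move with a simple alkyl chain such as n-butyl on the same nitrogen, which would show whether compound 1 and compound 3 mark the ends of the range at this position or only two points within it.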